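Cytotoxicity at the Limit: The Step to Compound 4

This account rests on a few compounds, and the source may have more. Where it says the series, first, only, none or still open, it means among the compounds named here.

Compound 1 `COc1ccc(C(=O)/C=C/c2ccc(OCCCOc3ccccc3)c(OC)c2)c(O)c1`: > 100000 nM (a limit)
Compound 2 `COc1ccc(C(=O)/C=C/c2ccc(C(=O)N3CCCC3)cc2)c(O)c1`: > 100000 nM (a limit)
Compound 3 `COc1ccc(C(=O)/C=C/c2cc(OC)c(OC)cc2OC)c(O)c1`: > 100000 nM (a limit)

All three compounds were tested in an ADME assay on SH-SY5Y cells (Homo sapiens) for cytotoxicity, read by MTT assay, with a stated time of 48 h (on this read-out lower numbers stand for stronger inhibition and higher numbers for weaker inhibition), and what they share is the limit of > 100000 nM in this assay, at which 3 of the 3 values shown sit. Compound 2 reads > 100000 nM, which is a limit and not a number. It therefore has no exact position among the three.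

Compound 4 `CCCNC(=O)c1ccc(/C=C/C(=O)c2ccc(OC)cc2O)cc1` has not yet been measured. It differs from compound 2 in one place: propylamino in place of pyrrolidin-1-yl on a carbonyl carbon. This puts propylamino in place of pyrrolidin-1-yl on a carbonyl carbon.

Going by the values given here, no step between measured compounds is available to show how far such a change might move the read-out. In this assay, no shift beyond the usual scatter is expected, an expectation that rests on compound 2 at > 100000 nM. The expected change is a number no higher from compound 2 to compound 4 (the limit leaves the size open). Compound 4 may also be reported only as a limit. As a number, compound 4 is estimated at 100000 nM, with an expected range from 40000 nM to 200000 nM.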

Compound 4, half-maximal inhibitory concentration: > 100000 nM
Compound 4 ended at the assay's limit; the forecaster's own chance of this, stated with the estimate: 80%; the middle value lies on the limit itself.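

Compound 2 and compound 4 both end at a limit rather than a number, so no step can be read between them: the limit of > 100000 nM in this assay, at which 4 of the 4 values shown sit.

The compounds shown leave open whether propylamino in place of pyrrolidin-1-yl shifts the read-out at all, since none has an exact value.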